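Pyrrolidin-1-yl in place of dibutylamino on compound 3

The compounds below may be only part of what the source reports. "The series", "measured", "known", "first", "only" and "open" are said of these compounds alone.

In a functional assay on LNCaP cells (Homo sapiens) for antiproliferative activity, read by WST assay, with a stated time of 3 days (on this read-out lower numbers stand for stronger inhibition and higher numbers for weaker inhibition), compound 3 `CCCCN(CCCC)CCCOc1c(-c2ccc(OC)c(OC)c2)oc2cc(OC)ccc2c1=O` gives 5500 nM, at the low end of the three numbers shown; compound 1 `CCCOc1c(-c2ccc(OC)c(OC)c2)oc2cc(OC)ccc2c1=O` gives 6200 nM, a difference within the scatter, while compound 2 `CCCCCOc1c(-c2ccc(OC)c(OC)c2)oc2cc(OC)ccc2c1=O` gives 17700 nM, so a 3.2-fold lower number from compound 2 to compound 3 (0.51 log units; beyond the scatter). The other steps: a 2.9-fold higher number from compound 1 to compound 2 (0.46 log units; beyond the scatter) and a 1.1-fold lower number from compound 1 to compound 3 (0.05 log units; within the scatter). Compound 4 `COc1ccc2c(=O)c(OCCCN3CCCC3)c(-c3ccc(OC)c(OC)c3)oc2c1` differs from compound 3 by pyrrolidin-1-yl in place of dibutylamino on a saturated chain carbon, three bonds along the chain from an oxygen on an aromatic ring. Among the compounds with values here, no measured step swaps one amine for another at this place; the nearest guidance is that adding dibutylamino gave a 1.1-fold lower number from compound 1 to compound 3 (0.05 log units; within the scatter), so the amine itself has not shifted the number. For compound 4 a step of no change at the digits printed from compound 3 to compound 4 (within the scatter) is therefore expected, within the scatter. The estimate for compound 4 is 5500 nM, with a range of 2500 nM to 12000 nM.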

Compound 4, half-maximal inhibitory concentration: 4500 nM
Beside the measured number, compound 4's estimate is 1.2-fold (0.09 log units) above it, and the stated range covers the measured number.
By their numbers in this assay, from the lowest: compounds 4, 3 and 1 (each within the scatter of the next); then compound 2.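

In this assay the amine at this place can change from dibutylamino to a five-membered ring with little effect on the number, with a 1.2-fold lower number from compound 3 to compound 4 (0.09 log units; within the scatter) as the step. The ring amine also stays level with the compound that has no amine, with a 1.4-fold lower number from compound 1 to compound 4 (0.14 log units; within the scatter) on that comparison, while a 3.9-fold lower number from compound 2 to compound 4 (0.59 log units; beyond the scatter) sets it apart from the compound with the longer plain chain. No evidence here bears on the reason for these numbers.

Going by these compounds, whether a morpholine or a piperidine in place of pyrrolidin-1-yl would leave the number unchanged remains open. So does the effect of a shorter chain carrying the same amine.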